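A Trifluoromethyl Group Added to an Anilide

The source may hold more compounds than are shown below. What is called first, only, known or untested is meant among the compounds shown, and "the series" means these compounds.

Measured so far in an assay on isolated protein for inhibition of histone deacetylase 4 (Homo sapiens), tested at 1 uM; on this read-out lower numbers stand for less inhibition and higher numbers for more inhibition at the one concentration tested (going by the name of the read-out):
compound 1 `CC(C)[C@@H](C(=O)Nc1ccc(C(=O)Nc2ccccc2N)cc1)c1ccccc1` — 9%
compound 2 `CC(C)[C@H](C(=O)Nc1ccc(C(=O)Nc2ccccc2N)cc1)c1ccccc1` — 0%

Compound 1 gives the highest of these two numbers, and compound 2 lies a number 9 percentage points lower from compound 1 to compound 2 (within the scatter); the two differ only in configuration as drawn (the fact that compounds 1 and 2 differ only in the configuration as drawn). Compound 3 `CC(C)[C@@H](C(=O)Nc1ccc(C(=O)Nc2ccc(C(F)(F)F)cc2N)cc1)c1ccccc1` changes compound 1 in one place: trifluoromethyl in place of hydrogen on an aromatic carbon. Within the data shown here, no measured step involves such a change, so there is nothing to scale an expectation from. Among the measured compounds shown here, the single measured step was within the scatter, and compound 3 is expected to stay near compound 1, with a number 1 percentage points higher from compound 1 to compound 3 (within the scatter). In this assay compound 3 is therefore estimated at 10%, between 0% and 30%.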

Compound 3, a percentage reported as inhibition, at one concentration (the size of the read-out at that concentration, not a potency): 3%
Estimate against measurement, compound 3: 7 percentage points above; the range from low to high includes it.
By their numbers in this assay, from the lowest: compounds 2, 3 and 1 (each within the scatter of the next).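

Placed meta to an amino group and para to a large group, trifluoromethyl in place of hydrogen gives a number 6 percentage points lower from compound 1 to compound 3 (within the scatter) in this assay. This position therefore carries the added group without a reading that can be told apart from compound 1, although compound 1 itself gives only 9%, which leaves little room to show a loss. No available evidence explains this result.

On these data alone, whether a methoxy group or a carboxylic acid on the same carbon would read differently stays open. So does whether trifluoromethyl would act alike in compound 2.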